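From Ethyl Ester to Free Acid in This Series

The compounds below may be only part of what the source reports. "The series", "measured", "known", "first", "only" and "open" are said of these compounds alone.

Among the measured compounds shown here, in a physicochemical assay for lipophilicity, using the shake flask method, measured as octanol-water partition, at pH 7.4 (on this read-out lower numbers stand for lower lipophilicity and higher numbers for higher lipophilicity), compound 2 `CCOC(=O)/C=C/c1ccc(OCCCCCCCCN(CC)CC)c(OC)c1` gives 1.98, one of only two numbers so far; the other belongs to compound 1 `CCOC(=O)/C=C/c1ccc(OCCCCCCN2CCCCC2)c(OC)c1`, which gives 1.81, and the step of a number 0.17 log units higher from compound 1 to compound 2 (within the scatter) lies within the scatter. Compound 3 `CCN(CC)CCCCCCCCOc1ccc(/C=C/C(=O)O)cc1OC` differs from compound 2 by hydrogen in place of ethyl on an oxygen next to a carbonyl group, that is, ethoxycarbonyl to carboxy. For the measured compounds named here, no measured step touches this change; the single known step concerns a different part of the structure and offers no guide. For compound 3 the estimate in this assay is -0.2, within -1.2 to 0.8. This estimate means an expected step of a number 2.18 log units lower from compound 2 to compound 3 (beyond the scatter).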

Compound 3, partition coefficient: 1.51
Compound 3: the middle estimate sits 1.71 log units below what was measured; measured number above the stated range.
By their numbers in this assay, from the lowest: compounds 3, 1 and 2 (each within the scatter of the next, the first and the last beyond it).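

In this assay, putting hydrogen in place of the ethyl, which turns ethoxycarbonyl into carboxy, gives a number 0.47 log units lower from compound 2 to compound 3 (beyond the scatter). Among the compounds shown here, this is the first measured change at this position, and it shows that the read-out responds to it, though only modestly. Nothing measured here explains the size of this step. On these data alone, whether the same change gives a similar step with the piperidin-1-yl chain of compound 1 remains open. So does the result for a primary amide or a methyl ester at this position.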